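Working notes: nitro to amino on a shared core

This account rests on a few compounds, and the source may have more. Where it says the series, first, only, none or still open, it means among the compounds named here.

Measured compounds in an ADME assay on Vero cells (Chlorocebus sabaeus) for cytotoxicity; a higher number here means that more compound is tolerated, a lower number that less compound is tolerated:
- compound 1 `Nc1ccc(-c2nc3cc(Cl)c(Cl)cc3[nH]2)cc1`: >= 100000 nM, a limit of the assay
- compound 2 `COc1ccc(-c2nc3cc(Cl)c(Cl)cc3[nH]2)c([N+](=O)[O-])c1`: 80000 nM
- compound 3 `O=[N+]([O-])c1ccc(-c2nc3cc(Cl)c(Cl)cc3[nH]2)cc1`: >= 100000 nM, a limit of the assay

For the measured compounds named here, compound 2 holds the only plain number in this assay. The change from compound 3 to compound 1 is amino in place of nitro on an aromatic carbon; its size is a step that the two limits leave unreadable from compound 3 to compound 1, unreadable because both values sit at the limit of >= 100000 nM in this assay, at which 2 of the 3 values shown sit. The difference between the cores of compound 2 and compound 3 is not broken down here.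

Compound 4 `COc1ccc(-c2nc3cc(Cl)c(Cl)cc3[nH]2)c(N)c1` is not yet measured. The change from compound 2 to compound 4 is amino in place of nitro on an aromatic carbon, the same kind of change as from compound 3 to compound 1, with a different surrounding: ortho to a large group and meta to a methoxy group, where the earlier one was para to a large group.

The step expected from compound 2 to compound 4 in this assay is a 1.3-fold higher number from compound 2 to compound 4 (0.10 log units; within the scatter). This rests on compound 2 giving 80000 nM and on the earlier step that the two limits leave unreadable from compound 3 to compound 1 being unreadable. For compound 4 the estimated value is 100000 nM, expected between 40000 nM and 250000 nM, with a fair chance of only a limit.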

Compound 4, half-maximal cytotoxic concentration: 75000 nM
Beside the measured number, compound 4's estimate is 1.3-fold (0.12 log units) above it; the measured number falls inside the stated range.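

In this assay the step for amino in place of nitro, ortho to a large group and meta to a methoxy group, is a 1.1-fold lower number from compound 2 to compound 4 (0.03 log units; within the scatter) and so stays within the scatter. This gives one readable pair, and it does not show that the change behaves alike on both cores, nor that a result on one core can be carried to the other. The earlier step on the core of compound 3 cannot be read, because compound 3 and compound 1 both stand at a limit and not at a plain number: the limit of >= 100000 nM in this assay, at which 2 of the 4 values shown sit.

The compounds shown leave open whether a different group in the same place, such as a carboxylic acid, a nitrile or a longer chain, would move the number in this assay beyond the scatter. They also leave open whether a hydroxyl or an ethoxy group in place of the methoxy group would alter the step seen for amino in place of nitro.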